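The compounds below may be only part of what the source reports. "The series", "measured", "known", "first", "only" and "open" are said of these compounds alone.

Of the compounds shown here, two have been measured so far. Compound 1 `O=C1OC(C(O)Cn2cc(C(F)(F)F)c(=O)[nH]c2=O)C(OCc2ccccc2)=C1OCc1ccccc1` gives 50200 nM in an ADME assay on L1210/0 cells (Mus musculus) for cytotoxicity, with a stated time of 48 h; a lower number here means a stronger inhibitor, a higher number a weaker inhibitor. Compound 2 `O=C(CI)NCc1cn([C@H]2C[C@H](O)[C@@H](CO)O2)c(=O)[nH]c1=O` gives 107000 nM in this assay, the higher of the two numbers, and the gap between compound 1 and compound 2 lies beyond the usual scatter, so compound 2 is the weaker inhibitor of the pair.

Compound 3 `CCC#Cc1cn([C@H]2C[C@H](O)[C@@H](CO)O2)c(=O)[nH]c1=O` is not yet measured. It differs from compound 2 in one place: but-1-yn-1-yl in place of (((iodomethyl)carbonyl)amino)methyl on an aromatic carbon. Among the measured compounds shown here, no measured pair in this set shows the effect of such a swap, so the expectation rests on the two numbers alone. Both are weak, and a change of this kind is expected to shift the number toward a lower value by a moderate step, although a result within the scatter would not be surprising. The expected step from compound 2 to compound 3 is a 3.6-fold lower number from compound 2 to compound 3 (0.55 log units; beyond the scatter). Compound 3 is estimated at 30000 nM, with a likely range from 4000 nM to 200000 nM.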

Compound 3, half-maximal inhibitory concentration: > 200000 nM
Compound 3: no number, only a limit (the forecaster's own chance of this, stated with the estimate: 20%); middle value at least 6.6-fold (0.82 log units) away from the limit.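

In this assay, putting but-1-yn-1-yl in place of (((iodomethyl)carbonyl)amino)methyl on this aromatic carbon gives an at least 1.8-fold higher number from compound 2 to compound 3 (0.27 log units; that floor lies within the scatter), so this change at this position brings no lower number. Compound 3 gives > 200000 nM, which is a limit of the assay and not a number. The true size of the step cannot be read, and whether compound 3 is really the weaker of the pair stays unsettled, because only a floor is known: the limit of > 200000 nM in this assay, at which 1 of the 3 values shown sits.

The two groups differ in several features at once, so these compounds cannot show whether the iodine, the carbonyl or the amide hydrogen matters most for compound 2. On these data alone, it also remains open whether a simple amine or a carboxylic acid on this aromatic carbon would give a measurable number.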